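Oxazolyl in place of ethylcarbamoyl on the shared core

The source may report more compounds than this note shows. Statements on the series, on what has been measured and on what is new or still open speak of the compounds shown alone.

Compound 3 `CCNC(=O)C1=C(C)NC(=O)NC1c1cccs1` is the reference point. In an assay on membranes from CHO cells for displacement of a labelled ligand from adenosine receptor A1 (Homo sapiens), read by scintillation counting, with a stated time of 60 min, tested at 1 uM (a higher number here means more inhibition at the concentration tested (going by the name of the read-out), a lower number less inhibition), compound 3 gives 1%. Compound 1 `CC1=C(C(=O)C2CC2)C(c2cccs2)NC(=O)N1` gives 1%, and compound 2 `CCNC(=O)C1=C(C)NC(=O)NC1c1ccco1` gives 2%; the step of no change at the digits printed from compound 1 to compound 3 (within the scatter) and the step of a number 1 percentage points lower from compound 2 to compound 3 (within the scatter) both leave compound 3 among the lowest of the three numbers, all within the scatter of one another.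

Compound 4 `CC1=C(c2ncc(C)o2)C(c2cccs2)NC(=O)N1` differs from compound 3 by 5-methyl-1,3-oxazol-2-yl in place of ethylcarbamoyl on a double-bonded ring carbon. Going by the values given here, the only measured step touching that same double-bonded ring carbon is no change at the digits printed from compound 1 to compound 3 (within the scatter), which bears directly on this change. The step of a number 2 percentage points higher from compound 3 to compound 4 (within the scatter) is therefore expected to stay inside the scatter, with no direction claimed. Compound 4 is estimated at 3%, within a range from -6% to 14%.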

Compound 4, a percentage reported as inhibition, at one concentration (the size of the read-out at that concentration, not a potency): 21%
Compound 4: the middle estimate sits 18 percentage points below what was measured; measured number outside the range, above it.
By their numbers in this assay, from the lowest: compounds 1, 3 and 2 (each within the scatter of the next); then compound 4.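

In this assay the 5-methyl-1,3-oxazol-2-yl group in place of ethylcarbamoyl (a number 20 percentage points higher from compound 3 to compound 4 (beyond the scatter)) and in place of cyclopropylcarbonyl (a number 20 percentage points higher from compound 1 to compound 4 (beyond the scatter)) raises the number by the same printed amount. This double-bonded ring carbon therefore responds to substitution, although the exchange between the two carbonyl-bearing groups left the value unchanged at the digits printed. No evidence accounts for the rise.

As far as these compounds go, whether it belongs to the aromatic ring or to its methyl group stays open, as does the outcome with unsubstituted oxazol-2-yl, thiazol-2-yl or phenyl at this carbon.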